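Methoxy to nitro on a trifluoromethyl carbonyl compound

The source may report more compounds than this note shows. Statements on the series, on what has been measured and on what is new or still open speak of the compounds shown alone.

compound 1 `COc1ccc(-c2noc(CCCCCCC(=O)NO)n2)cc1`: 3650 nM
compound 2 `Nc1ccccc1NC(=O)CCCCCCc1nc(-c2ccc([N+](=O)[O-])cc2)no1`: 10300 nM
compound 3 `COc1ccc(-c2noc(CCCCCCC(=O)C(F)(F)F)n2)cc1`: 1170 nM

In a functional assay on U-937 cells (Homo sapiens) for antiproliferative activity, read by MTT assay, with a stated time of 72 h (a lower number here means a stronger inhibitor, a higher number a weaker inhibitor), compound 3 gives 1170 nM as the lowest of the three numbers, which makes it the strongest inhibitor measured so far. Compound 4 `O=C(CCCCCCc1nc(-c2ccc([N+](=O)[O-])cc2)no1)C(F)(F)F` differs from it in one place: nitro in place of methoxy on an aromatic carbon.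

Among the compounds with values here, the only measured step, a 3.1-fold lower number from compound 1 to compound 3 (0.49 log units; beyond the scatter), swaps hydroxyamino for trifluoromethyl on a carbonyl carbon and leaves the methoxy untouched, so it says nothing direct about this change. Nitro appears only in compound 2 at 10300 nM, and that compound also carries a different group on its carbonyl, so its value cannot isolate the nitro. Within the data shown here, with no measured step on this swap, the expectation is a small change, leaning slightly upward and uncertain in size: an estimated 1.4-fold higher number from compound 3 to compound 4 (0.14 log units; within the scatter) is the working guess. Compound 4 is expected near 1600 nM in an estimated range of 550 nM to 4500 nM in this assay.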

Compound 4, half-maximal inhibitory concentration: 3680 nM
For compound 4 the middle estimate is 2.3-fold (0.36 log units) below the measured one; low and high end bracket the measured number.
By their numbers in this assay, from the lowest: compound 3; then compounds 1 and 4 (each within the scatter of the next); then compound 2.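

In this assay, nitro in place of methoxy on an aromatic carbon, with the trifluoromethyl carbonyl kept, gives a 3.1-fold higher number from compound 3 to compound 4 (0.50 log units; beyond the scatter), so this position does affect the number, and methoxy gives the stronger inhibitor of the two. With nitro held constant, trifluoromethyl in place of (2-aminophenyl)amino on the carbonyl carbon gives a 2.8-fold lower number from compound 2 to compound 4 (0.45 log units; beyond the scatter), which shows that the group on the carbonyl also counts when nitro sits on the aromatic ring. No measurement available here explains why either step goes the way it does.

The compounds shown leave open how an amine or a plain hydrogen on this aromatic carbon would compare with methoxy and nitro. They also leave open whether the methoxy to nitro swap gives a similar step when hydroxyamino sits on the carbonyl, or with a longer chain.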